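Moving a methyl around the aryl ether ring

This account rests on a few compounds, and the source may have more. Where it says the series, first, only, none or still open, it means among the compounds named here.

Compound 2 `CN1CCN(c2nc(N)nc(COc3ccc(Cl)cc3Cl)n2)CC1` and compound 1 `Cc1cc(Cl)ccc1OCc1nc(N)nc(N2CCN(C)CC2)n1` share one core and differ only in the aryl ether end. In an assay on HEK293 cells for displacement of a labelled ligand from 5-hydroxytryptamine receptor 7 (Homo sapiens), read by radioligand binding, with a stated time of 1 h (a lower number here means a stronger inhibitor, a higher number a weaker inhibitor), compound 2 gives 3800 nM, while compound 1 gives 15200 nM. Among the compounds with values here, the single step on record, a 4.0-fold lower number from compound 1 to compound 2 (0.60 log units; beyond the scatter), comes from a chloro replacing a methyl on an aromatic carbon, and leaves compound 2 with the lowest of the two numbers so far. Compound 3 `Cc1cc(OCc2nc(N)nc(N3CCN(C)CC3)n2)ccc1Cl` changes the same end again: 4-chloro-3-methylphenyl in place of 2,4-dichlorophenyl on an oxygen on a saturated carbon. This undoes the gain of a second chloro and brings a methyl back, though at a different spot on the ring than in compound 1, so the recorded step bears on it only by analogy. Because compound 1 with its methyl gave 15200 nM, compound 3 is expected to land nearer that value than to compound 2, a step of roughly a 2.4-fold higher number from compound 2 to compound 3 (0.37 log units; beyond the scatter). The estimate for compound 3 is 9000 nM, with a range from 3000 nM to 30000 nM.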

Compound 3, inhibition constant: 5840 nM
The estimate for compound 3 lay 1.5-fold (0.19 log units) above the measured number, and the stated range covers the measured number.
By their numbers in this assay, from the lowest: compounds 2 and 3 (each within the scatter of the next); then compound 1.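

A methyl on this ring does not by itself give a weaker compound: in this assay, 4-chloro-3-methylphenyl in place of 2,4-dichlorophenyl gives a 1.5-fold higher number from compound 2 to compound 3 (0.19 log units; within the scatter), so compound 2 and compound 3 cannot be told apart. Where the methyl stands does count, as 4-chloro-3-methylphenyl in place of 4-chloro-2-methylphenyl gives a 2.6-fold lower number from compound 1 to compound 3 (0.42 log units; beyond the scatter), a modest change from moving one group on the same ring. No measurement at hand explains why these two rings differ.

The compounds shown leave open whether the chloro in 4-chloro-3-methylphenyl is needed at all. They also leave open how a methoxy group or a nitrile on this ring would compare with the chloro and methyl groups seen so far.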